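A few compounds are considered here, and "the series" means these few. Any claim that something is new, unique, unknown or untested is made for them only; others in the source may bear on it.

Measured compounds:
- compound 1 `CN1C/C(=C\c2ccc(C#N)cc2)C(=O)/C(=C/c2ccccc2F)C1` gives 1340 nM
- compound 2 `COc1cc(/C=C2\CN(C)C/C(=C\c3ccc(F)cc3)C2=O)cc(OC)c1` gives 10200 nM
- compound 3 `COc1cc(/C=C2\CN(C)C/C(=C\c3ccc(F)cc3)C2=O)cc(OC)c1OC` gives 7250 nM

In a functional assay on HeLa cells (Homo sapiens) for cytotoxicity, read by MTT assay, with a stated time of 24 h (a higher number here means a weaker inhibitor, a lower number a stronger inhibitor), compound 3 stands at 7250 nM, within the scatter of compound 2, while compound 1 gives a clearly lower number. Compound 4 `COc1cc(/C=C2\CN(C)C/C(=C\c3cccc([N+](=O)[O-])c3)C2=O)cc(OC)c1OC` is still unmeasured. It differs from compound 3 thus: 3-nitrophenyl in place of 4-fluorophenyl on a double-bonded chain carbon bound to a double-bonded ring carbon.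

For the measured compounds named here, the only measured step, a 1.4-fold lower number from compound 2 to compound 3 (0.15 log units; within the scatter), is methoxy in place of hydrogen on an aromatic carbon, so it says little about this change. Compound 1, at 1340 nM, shows that lower numbers occur, but it differs from compound 3 in more than one place. No step beyond the scatter is therefore expected, and the estimated move is a 1.3-fold lower number from compound 3 to compound 4 (0.12 log units; within the scatter). For compound 4 the expected value is 5500 nM, with an estimated range from 1800 nM to 15000 nM.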

Compound 4, half-maximal inhibitory concentration: 5540 nM
Compound 4: the middle estimate sits 1.0-fold (0.00 log units) below what was measured; low and high end bracket the measured number.
By their numbers in this assay, from the lowest: compound 1; then compounds 4, 3 and 2 (each within the scatter of the next).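

In this assay, the change at this place gives a 1.3-fold lower number from compound 3 to compound 4 (0.12 log units; within the scatter). The methoxy step could not show it, but on a double-bonded chain carbon bound to a double-bonded ring carbon, 4-fluorophenyl can give way to 3-nitrophenyl, with 9 heavy atoms instead of 7 and 2 hydrogen-bond acceptors, without a step beyond the scatter. Nothing available explains why these two groups read alike. Still open, from the compounds shown here alone, is whether a phenyl carrying an amine or a carboxylic acid, or a longer chain, at this place would give a step beyond the scatter.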